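Swapping fluoro for methoxy on a sulfonamide aryl ring

The compounds below may be only part of what the source reports. "The series", "measured", "known", "first", "only" and "open" are said of these compounds alone.

Three compounds share one core, a benzoxazole-bearing aniline capped by an arylsulfonamide; they differ only in the ring attached to the sulfonyl sulfur. Compound 1 `Cc1ccc(S(=O)(=O)Nc2ccc(-c3nc4ccccc4o3)cc2)cc1` carries a 4-methylphenyl there and gives 88000 nM in an ADME assay on HEK293 cells (Homo sapiens) for cytotoxicity, read by resazurin assay, with a stated time of 48 h; a higher number here means that more compound is tolerated, a lower number that less compound is tolerated. Compound 2 `O=S(=O)(Nc1ccc(-c2nc3ccccc3o2)cc1)c1ccccc1F` carries a 2-fluorophenyl instead. In this assay compound 2 reaches only the upper limit of the assay, > 100000 nM, so no exact number is known for it. Going by the values given here, the one measured step, an at least 1.1-fold higher number from compound 1 to compound 2 (0.05 log units; that floor lies within the scatter), is therefore only a floor, and its size sits within the scatter; it rests on (the limit of > 100000 nM in this assay, at which 1 of the 2 values shown sits).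

Compound 3 `COc1ccccc1S(=O)(=O)Nc1ccc(-c2nc3ccccc3o2)cc1` is the next variation: methoxy in place of fluoro on an aromatic carbon. Among the compounds with values here, no measured step involves a methoxy group, so the only guide is that the change from compound 1 to compound 2 did not lower tolerance. In this assay the step of a number no higher from compound 2 to compound 3 (the limit leaves the size open) is expected to stay within the scatter, with a fair chance that compound 3 again ends at the limit. The estimate for compound 3 is 100000 nM, in a range from 45000 nM to 250000 nM.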

Compound 3, half-maximal cytotoxic concentration: > 100000 nM
Compound 3 was reported as a limit (the forecaster's own chance of this, stated with the estimate: 60%); the middle value lies on the limit itself.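

The 2-methoxyphenyl ring now joins the 2-fluorophenyl ring at the limit of this assay, so two different groups ortho to a large group have both been tolerated up to the top of the range this test can read. Measured against the 4-methylphenyl ring of compound 1, the new compound shows an at least 1.1-fold higher number from compound 1 to compound 3 (0.05 log units; that floor lies within the scatter), which adds a second floor of the same small size rather than a measured gain, so neither ring can be said to differ from the 4-methylphenyl ring. The swap of fluoro for methoxy itself cannot be read, because compound 2 and compound 3 are both reported only as limits: the limit of > 100000 nM in this assay, at which 2 of the 3 values shown sit.

As far as these compounds go, the true numbers of compound 2 and compound 3 remain unknown, and with them whether fluoro and methoxy differ at all in this test. Also open, from the compounds shown here alone, is whether a different kind of group on this ring, such as an amine or a carboxylic acid, would still reach the limit or would bring the tolerated concentration down into the readable range.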